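A few compounds are considered here, and "the series" means these few. Any claim that something is new, unique, unknown or untested is made for them only; others in the source may bear on it.

Series notes. The shared core is that of compound 1 `CCCCNc1nc(N)nc(C)c1CCCc1ccccc1`; the measured compounds vary only the group on the saturated chain carbon, three bonds along the chain from an aromatic carbon. In an assay on HEK293 cells for agonist activity at Toll-like receptor 8 (Homo sapiens), read by spectrophotometry (a higher number here means that more compound is needed for the effect, a lower number that less compound is needed), compound 1 gives 749 nM, the second highest of the three numbers. Compound 2 `CCCCNc1nc(N)nc(C)c1CCCN1CCCCCC1` gives 178 nM in this assay, and compound 3 `CCCCNc1nc(N)nc(C)c1CCCn1cccn1` gives 1050 nM. The steps read a 4.2-fold lower number from compound 1 to compound 2 (0.62 log units; beyond the scatter), a 1.4-fold higher number from compound 1 to compound 3 (0.15 log units; within the scatter) and a 5.9-fold higher number from compound 2 to compound 3 (0.77 log units; beyond the scatter).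

Compound 4 `CCCCNc1nc(N)nc(C)c1CCCC`, not yet measured, differs from compound 1 in one place: methyl in place of phenyl on a saturated chain carbon, three bonds along the chain from an aromatic carbon. Among the measured compounds shown here, no measured step replaces phenyl with a group lacking a ring, so the bearing of the measured steps is indirect: one ring-for-ring swap stayed within the scatter, the other gave a modest lowering. Removing the ring altogether is read as more likely to cost than to gain. For compound 4 the step in this assay is expected to be a 1.9-fold higher number from compound 1 to compound 4 (0.27 log units; within the scatter). The estimate for compound 4 is therefore 1400 nM, with a range from 500 nM to 4500 nM.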

Compound 4, half-maximal effective concentration: 780 nM
The estimate for compound 4 lay 1.8-fold (0.25 log units) above the measured number; the measured number falls inside the stated range.
By their numbers in this assay, from the lowest: compound 2; then compounds 1, 4 and 3 (each within the scatter of the next).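

In this assay, the ring on this saturated chain carbon proves dispensable for the numbers seen with phenyl and 1H-pyrazol-1-yl: methyl serves as well as phenyl (a 1.0-fold higher number from compound 1 to compound 4 (0.02 log units; within the scatter)) and as well as 1H-pyrazol-1-yl (a 1.3-fold lower number from compound 3 to compound 4 (0.13 log units; within the scatter)). Azepan-1-yl alone stands apart from methyl (a 4.4-fold higher number from compound 2 to compound 4 (0.64 log units; beyond the scatter)), so among these compounds the lower number belongs to compound 2 and not to the presence of a ring as such, with compounds 1 and 3 going against any general ring benefit. No supporting evidence on the origin of this difference is available.

Going by these compounds, whether the lower number persists with a smaller ring amine such as pyrrolidin-1-yl or an open-chain amine such as diethylamino remains open. On these data alone, the reading of a longer chain or a carboxylic acid on this carbon is also open.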